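Swapping 1,3-benzoxazol-2-yl for 1-(pyridin-2-yl)ethyl

This account rests on a few compounds, and the source may have more. Where it says the series, first, only, none or still open, it means among the compounds named here.

In a functional assay for inhibition, with Homo sapiens as the target (a higher number here means a weaker inhibitor, a lower number a stronger inhibitor), compound 1 `CC(C)(C)Sc1c(CC(C)(C)C(=O)O)n(Cc2ccc(Cl)cc2)c2ccc(OCc3ccc4cc(F)ccc4n3)cc12` gives 2 nM and compound 2 `CC(C)(C)Sc1c(CC(C)(C)C(=O)O)n(Cc2ccc(Cl)cc2)c2ccc(OCc3cc4ccccc4cn3)cc12` gives 3 nM. Compound 3 `CC(C)(C)Sc1c(CC(C)(C)C(=O)O)n(Cc2ccc(Cl)cc2)c2ccc(OCc3nc4ccccc4o3)cc12` gives < 7 nM, which is a limit and not a number. Compound 4 `C[C@@H](COc1ccc2c(c1)c(SC(C)(C)C)c(CC(C)(C)C(=O)O)n2Cc1ccc(Cl)cc1)c1ccccn1` differs from compound 3 in one place: 1-(pyridin-2-yl)ethyl in place of 1,3-benzoxazol-2-yl on a saturated chain carbon bound to an oxygen on an aromatic ring. For the measured compounds named here, the only readable step at this place is the swap of 6-fluoroquinolin-2-yl for isoquinolin-3-yl, a 1.5-fold higher number from compound 1 to compound 2 (0.18 log units; within the scatter). The limit hides the size of the other two, a step that the limit leaves unreadable from compound 1 to compound 3 and a step that the limit leaves unreadable from compound 2 to compound 3. Going by the values given here, no measured compound carries 1-(pyridin-2-yl)ethyl, so any forecast here is uncertain. The expected step is an at least 1.4-fold higher number from compound 3 to compound 4 (0.15 log units; that floor lies within the scatter), a modestly higher number in this assay. For compound 4 the estimated value is 10 nM, with an expected range of 3 nM to 40 nM.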

Compound 4, half-maximal inhibitory concentration: 2 nM
Beside the measured number, compound 4's estimate is 5.0-fold (0.70 log units) above it; measured number outside the range, below it.
By their numbers in this assay, from the lowest: compounds 1, 4 and 2 (each within the scatter of the next).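

In this assay, for the compounds shown here, this position accepts a group with a single aromatic ring as readily as the two-ring groups of the earlier compounds: 1-(pyridin-2-yl)ethyl, which also brings a defined stereocentre, gives no change at the digits printed from compound 1 to compound 4 (within the scatter) and a 1.5-fold lower number from compound 2 to compound 4 (0.18 log units; within the scatter). Compound 3 carries a limit and not a number, so its step to compound 4 cannot be read: the limit of < 7 nM in this assay, at which 1 of the 4 values shown sits.

Still open, going by these compounds, is how the mirror-image form of 1-(pyridin-2-yl)ethyl would read in this assay. Also open, on these data alone, is whether the ring nitrogen matters, which a 1-phenylethyl group at this place would test.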